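Series notes: methyl replaced by dichlorophenylcarbonyl on a ring amine

The compounds below may be only part of what the source reports. "The series", "measured", "known", "first", "only" and "open" are said of these compounds alone.

Measured so far:
compound 1 `COc1ccc2nccc(C3CN(CC4CCN(Cc5cc6ccccc6[nH]5)CC4)C(=O)O3)c2c1` — < 50200 nM
compound 2 `COc1ccc2nccc(C3CN(C4CCN(C)CC4)C(=O)O3)c2c1` — < 50200 nM

In an in vitro functional assay on RBL cells for antagonist activity at C-C chemokine receptor type 8 (Homo sapiens), read by FLIPR and calcium flux (on this read-out higher numbers stand for weaker inhibition and lower numbers for stronger inhibition), compound 1 gives < 50200 nM, which is a limit of the assay and not a number. In the same this assay compound 2 gives < 50200 nM, again a limit and not a number. Compound 2 therefore stands at the limit of < 50200 nM in this assay, at which 2 of the 2 values shown sit; no ordering between compound 1 and compound 2 can be drawn from what is shown, and no step between measured compounds is available.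

Compound 3 `COc1ccc2nccc(C3CN(C4CCN(C(=O)c5ccc(Cl)c(Cl)c5)CC4)C(=O)O3)c2c1` is the next compound to be run in this assay. Against compound 2 its change is (3,4-dichlorophenyl)carbonyl in place of methyl on an amine nitrogen in a ring. The two known values being limits, they give no direction for this change, and the step that the limit leaves unreadable from compound 2 to compound 3 is an expectation resting on the structural change alone. Compound 3 is estimated at 3000 nM, with a range from 100 nM to 50000 nM, and a real chance that the assay again returns only a limit.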

Compound 3, half-maximal inhibitory concentration: 6310 nM
Compound 3: the middle estimate sits 2.1-fold (0.32 log units) below what was measured; the measured number falls inside the stated range.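

For the compounds shown here, no step from compound 2 to compound 3 can be read, because the value of compound 2 is a limit of the assay and not a number: the limit of < 50200 nM in this assay, at which 2 of the 3 values shown sit.

The compounds shown leave open the size and direction of any shift in inhibition when (3,4-dichlorophenyl)carbonyl replaces methyl on an amine nitrogen in a ring.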